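Methyl to Methoxy in a Weakly Cytotoxic Pair

The source may report more compounds than this note shows. Statements on the series, on what has been measured and on what is new or still open speak of the compounds shown alone.

Compound 1, `O=C(CSC(=S)N[C@H]1CCOC1=O)Nc1ccc(Cl)cc1`: > 128000 nM, a limit of the assay rather than a number.
Compound 2, `Cc1ccc(NC(=O)CSC(=S)N[C@H]2CCOC2=O)cc1`: 93900 nM.

Within the data shown here, in a functional assay on EC9706 cells (Homo sapiens) for cytotoxicity, read by MTT assay, with a stated time of 72 h (a higher number here means a weaker inhibitor, a lower number a stronger inhibitor), compound 2 gives 93900 nM, the only plain number so far. Compound 1 in this assay reaches only (the limit of > 128000 nM in this assay, at which 1 of the 2 values shown sits), so the change of an at least 1.3-fold lower number from compound 1 to compound 2 (0.13 log units; that floor lies within the scatter) cannot be sized with confidence. Compound 3, `COc1ccc(NC(=O)CSC(=S)N[C@H]2CCOC2=O)cc1`, differs from compound 2 by methoxy in place of methyl on an aromatic carbon. Among the measured compounds shown here, no measured step concerns this exchange; the only step in hand, from chloro to methyl, lies within the scatter, and it points to a region where the assay often reports a limit. For compound 3 an expected step of a 1.1-fold higher number from compound 2 to compound 3 (0.05 log units; within the scatter) means no change beyond the scatter, and the result may again be a limit. The estimate for compound 3 in this assay is therefore 105000 nM, expected to fall between 45000 nM and 250000 nM.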

Compound 3, half-maximal inhibitory concentration: > 128000 nM
Compound 3 ended at the assay's limit; the forecaster's own chance of this, stated with the estimate: 40%; middle value at least 1.2-fold (0.08 log units) from the limit.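

The exchange of methyl for methoxy, on an aromatic carbon para to a large group, adds an oxygen and a hydrogen-bond acceptor, and in this assay it gives an at least 1.3-fold higher number from compound 2 to compound 3 (0.13 log units; that floor lies within the scatter). Among these compounds, this is the first sign that this added oxygen brings no clear gain in strength, although the true size of the step stays unknown, and the step between the two compounds that end at limits cannot be read. Chloro, methyl and methoxy at this position have therefore not been separated, and most of the series now rests at the edge of the read-out: the limit of > 128000 nM in this assay, at which 2 of the 3 values shown sit.

On these data alone, whether an amine or a carboxylic acid at this position would give a plain number well clear of that limit remains open. So does whether a longer chain there would do so.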